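Halogen on the benzyl ring of an indole methanol series

A few compounds are considered here, and "the series" means these few. Any claim that something is new, unique, unknown or untested is made for them only; others in the source may bear on it.

Measured so far in a functional assay on NCI-H460 cells (Homo sapiens) for cytotoxicity, read by sulforhodamine B assay, with a stated time of 3 days; on this read-out higher numbers stand for weaker inhibition and lower numbers for stronger inhibition:
- compound 1, `OCc1cn(Cc2ccccc2)c2ccccc12`, gives 112 nM
- compound 2, `OCc1cn(Cc2cccc(F)c2)c2ccccc12`, gives 40 nM
- compound 3, `OCc1cn(Cc2cccc(Cl)c2)c2ccccc12`, gives 19 nM

Compound 1 has the highest number of the three, so it is the weakest inhibitor here; the step of a 2.8-fold lower number from compound 1 to compound 2 (0.45 log units; beyond the scatter) and the step of a 5.9-fold lower number from compound 1 to compound 3 (0.77 log units; beyond the scatter) both lie beyond the scatter, and the step of a 2.1-fold lower number from compound 2 to compound 3 (0.32 log units; beyond the scatter) does too.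

Compound 4, `OCc1cn(Cc2ccc(Br)cc2)c2ccccc12`, is not yet measured. It differs from compound 1 by bromo in place of hydrogen on an aromatic carbon. The change is a bromo in place of hydrogen on an aromatic carbon, para to a large group.

For the measured compounds named here, no measured step places a bromo anywhere. The nearest guides are the fluoro and chloro steps from compound 1, both modest decreases in the number, with chloro the larger. On that basis compound 4 is expected to give a lower number than compound 1, by a step of about a 5.1-fold lower number from compound 1 to compound 4 (0.71 log units; beyond the scatter) in this assay. Compound 4 is therefore estimated at 22 nM, within a range of 8 nM to 65 nM.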

Compound 4, half-maximal inhibitory concentration: 31 nM
Compound 4: middle estimate off by 1.4-fold (0.15 log units), on the low side, within the range that was stated.
By their numbers in this assay, from the lowest: compounds 3, 4 and 2 (each within the scatter of the next, the first and the last beyond it); then compound 1.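

In this assay, bromo in place of hydrogen on an aromatic carbon, para to a large group, gives a 3.6-fold lower number from compound 1 to compound 4 (0.56 log units; beyond the scatter) and so shows that a halogen at this place on the ring also lowers the number. Compound 4 differs from compound 2 and from compound 3 in two things, the halogen and where it sits, so its value cannot separate the effect of the atom from the effect of the place. Nothing available explains why this bromo lowers the number.

Still open, going by these compounds, is how fluoro or chloro would behave at this same place, and how bromo would behave where compound 2 and compound 3 carry their halogens. Also open, on these data alone, is what a group other than a halogen, such as an amine, a carboxylic acid or a longer carbon chain, would do here.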